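The compounds below may be only part of what the source reports. "The series", "measured", "known", "first", "only" and "open" are said of these compounds alone.

Going by the values given here, compound 2 `COC(=O)CCNC(=O)C(=O)c1ccccc1NC(C)=O` gives the higher of the two numbers measured so far: in an assay on mitochondria from brain for inhibition of Amine oxidase [flavin-containing] B (Bos taurus) (a lower number here means a stronger inhibitor, a higher number a weaker inhibitor), compound 2 gives 990000 nM, whereas compound 1 `COC(=O)C[C@H](NC(=O)C(=O)c1ccccc1NC(C)=O)C(=O)OC` gives 460000 nM. Among the compounds with values here, the step of a 2.2-fold higher number from compound 1 to compound 2 (0.33 log units; beyond the scatter) is the only measured change on the chain bound to the amide-type nitrogen, and it removes a group rather than lengthening the chain. Compound 3 `COC(=O)CCCCCNC(=O)C(=O)c1ccccc1NC(C)=O` differs from compound 2 by 3-(methoxycarbonyl)propyl in place of methoxycarbonyl on a saturated chain carbon, two bonds along the chain from an amide-type nitrogen. Within the data shown here, no measured step tests a longer chain, so compound 3 is expected to move only a 1.2-fold lower number from compound 2 to compound 3 (0.09 log units; within the scatter), a step within the scatter. Compound 3 is therefore estimated at 800000 nM in this assay, between 300000 nM and 2500000 nM.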

Compound 3, half-maximal inhibitory concentration: 590000 nM
Beside the measured number, compound 3's estimate is 1.4-fold (0.13 log units) above it; the measured number falls inside the stated range.
By their numbers in this assay, from the lowest: compounds 1, 3 and 2 (each within the scatter of the next, the first and the last beyond it).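

In this assay, going by these compounds alone, putting 3-(methoxycarbonyl)propyl in place of methoxycarbonyl gives a 1.7-fold lower number from compound 2 to compound 3 (0.22 log units; within the scatter) and so stays within the scatter; this is the first measured test of a longer chain at this position. For this one pair, the added chain length produces no change that can be told apart from repeat variation. Nothing available explains this outcome.

On these data alone, whether a carboxylic acid or an amine in place of the methoxycarbonyl, or a still longer chain, would move the number beyond the scatter stays open.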